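Series notes: methyl in place of bromo, compound 4 estimate

This account rests on a few compounds, and the source may have more. Where it says the series, first, only, none or still open, it means among the compounds named here.

Compound 1 `CC(=O)Oc1ccc(/C=C/C(=O)OCCSc2nc(-c3ccc(S(C)(=O)=O)cc3)n(-c3ccc(F)cc3)n2)cc1OC(C)=O` gives 12800 nM in a functional assay on Caco-2 cells (Homo sapiens) for antiproliferative activity, read by MTT assay, with a stated time of 72 h; a lower number here means a stronger inhibitor, a higher number a weaker inhibitor. For the measured compounds named here, compound 2 `CC(=O)Oc1ccc(/C=C/C(=O)OCCSc2nc(-c3ccc(S(C)(=O)=O)cc3)n(-c3ccc(C(F)(F)F)cc3)n2)cc1OC(C)=O` gives 11300 nM in this assay, and the step of a 1.1-fold lower number from compound 1 to compound 2 (0.05 log units; within the scatter) is the only measured single-point change in the set. Compound 3 `COc1cc(/C=C/C(=O)OCCSc2nc(-c3ccc(S(C)(=O)=O)cc3)n(-c3ccc(Br)cc3)n2)ccc1OC(C)=O` gives 12100 nM in this assay, which places it second highest of the three numbers, with compound 1 nearest and compound 2 furthest, both differences within the scatter.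

Compound 4 `COc1cc(/C=C/C(=O)OCCSc2nc(-c3ccc(S(C)(=O)=O)cc3)n(-c3ccc(C)cc3)n2)ccc1OC(C)=O` differs from compound 3 only by methyl in place of bromo on an aromatic carbon. Going by the values given here, no measured step covers this exchange directly. Among the compounds with values here, the one step at the same place, a 1.1-fold lower number from compound 1 to compound 2 (0.05 log units; within the scatter), stays within the scatter, and the three measured values themselves lie within the scatter of one another. On that basis compound 4 is expected to show the step of no change at the digits printed from compound 3 to compound 4 (within the scatter) in this assay, that is, no change beyond the scatter. The estimate for compound 4 in this assay is therefore 12100 nM, with an expected range from 6000 nM to 24000 nM.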

Compound 4, half-maximal inhibitory concentration: 14100 nM
Compound 4: middle estimate off by 1.2-fold (0.07 log units), on the low side; the measured number falls inside the stated range.
By their numbers in this assay, from the lowest: compounds 2, 3, 1 and 4 (each within the scatter of the next).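

In this assay, for the compounds shown here, the step of a 1.2-fold higher number from compound 3 to compound 4 (0.07 log units; within the scatter) is the first measured exchange at this position on the core of compound 3, and 4-methylphenyl stands in for 4-bromophenyl without a change beyond the scatter. Going by these compounds alone, until now, the only measured exchange here ran from fluoro to trifluoromethyl on the core of compound 1, so the series now also holds a step in which a single bromine gives way to a single carbon, and this step likewise stays within the scatter. Nothing available bears on why this position shows so little response. Going by these compounds, whether an amine or a carboxylic acid on this ring would behave the same way in this assay remains open. Also open, on these data alone, is whether a longer chain here, such as butyl, would stay within the scatter.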